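Replacing the 4-ethylphenyl group on the sulfonamide nitrogen

The source may hold more compounds than are shown below. What is called first, only, known or untested is meant among the compounds shown, and "the series" means these compounds.

Of the compounds shown here, three have been measured so far: compound 1 (`O=C(/C=C/c1cccnc1)NCCCc1cccc(S(=O)(=O)Nc2ccccc2)c1`), compound 2 (`O=C(/C=C/c1cccnc1)NCCCCCCc1cccc(S(=O)(=O)Nc2ccccc2)c1`) and compound 3 (`CCc1ccc(NS(=O)(=O)c2cccc(CCCCCCNC(=O)/C=C/c3cccnc3)c2)cc1`). In a functional assay on MCF7 cells (Homo sapiens) for inhibition, read by CCK-8 assay, with a stated time of 72 h (a higher number here means a weaker inhibitor, a lower number a stronger inhibitor), compound 1 gives 142 nM, compound 2 gives 0.63 nM and compound 3 gives 3.64 nM. Compound 3 therefore has the second highest number of the three, much nearer to compound 2 than to compound 1.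

The next compound is compound 4 (`O=C(/C=C/c1cccnc1)NCCCCCCc1cccc(S(=O)(=O)Nc2ccc(F)c(Cl)c2)c1`), with 3-chloro-4-fluorophenyl in place of 4-ethylphenyl on a sulfonamide nitrogen. Among the compounds with values here, only one measured step bears on this change: a 5.8-fold higher number from compound 2 to compound 3 (0.76 log units; beyond the scatter), where ethyl replaces hydrogen on an aromatic carbon. That step is modest but beyond the scatter. Within the data shown here, no compound with chlorine or fluorine has been measured, so the direction rests on this single comparison. Losing the ethyl group may recover part of that step, which points towards compound 2 at 0.63 nM without necessarily reaching it. The expected change is a 2.4-fold lower number from compound 3 to compound 4 (0.39 log units; beyond the scatter), a modest move to a lower number. Compound 4 is estimated at 1.5 nM, with an expected range of 0.4 nM to 6 nM.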

Compound 4, half-maximal inhibitory concentration: 6.3 nM
The estimate for compound 4 lay 4.2-fold (0.62 log units) below the measured number, outside the stated range (above it).
By their numbers in this assay, from the lowest: compound 2; then compounds 3 and 4 (each within the scatter of the next); then compound 1.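

In this assay the exchange of 4-ethylphenyl for 3-chloro-4-fluorophenyl on the sulfonamide nitrogen gives a 1.7-fold higher number from compound 3 to compound 4 (0.24 log units; within the scatter) and so does not separate these two substituted rings. The comparison with the unsubstituted ring is the clearer reading: there is a 10-fold higher number from compound 2 to compound 4 (1.00 log units; beyond the scatter) for the halogenated ring and a 5.8-fold higher number from compound 2 to compound 3 (0.76 log units; beyond the scatter) for the ethyl-bearing ring, so among the three compounds sharing this chain both substituted rings read higher than phenyl, and none of the three goes against this. Nothing available explains why either substituted ring departs from phenyl.

Still open, from the compounds shown here alone, is whether chlorine alone or fluorine alone on this ring reads like phenyl or like 3-chloro-4-fluorophenyl, which would show whether one halogen or any substitution at all carries the step away from compound 2. Also open, going by these compounds, is whether an amine or a carboxylic acid on this ring behaves like the ethyl and halogen groups, and whether 3-chloro-4-fluorophenyl keeps the same standing on a longer chain or on the shorter chain of compound 1.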